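Removing the aryl group from a spiropiperidine sigma-1 ligand

This account rests on a few compounds, and the source may have more. Where it says the series, first, only, none or still open, it means among the compounds named here.

Measured so far in an assay on membranes from brain for displacement of a labelled ligand from Sigma non-opioid intracellular receptor 1 (Cavia porcellus), read by scintillation counting, with a stated time of 120 min; a higher number here means a weaker inhibitor, a lower number a stronger inhibitor:
compound 1 `COC1Cc2cc(-c3ccc(C(C)=O)cc3)sc2C2(CCN(Cc3ccccc3)CC2)O1`: 59 nM
compound 2 `COc1ccc(-c2csc3c2CC(OC)OC32CCN(Cc3ccccc3)CC2)cc1`: 7.1 nM
compound 3 `COC1Cc2c(-c3ccc(C)cc3)csc2C2(CCN(Cc3ccccc3)CC2)O1`: 2.7 nM

Compound 3 holds the lowest number of the three in this assay. Compound 2 is its nearest neighbour, with a 2.6-fold lower number from compound 2 to compound 3 (0.42 log units; beyond the scatter), while compound 1, whose aryl group sits on a different carbon of the shared core, gives a much higher number than compound 3.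

Compound 4 `COC1Cc2ccsc2C2(CCN(Cc3ccccc3)CC2)O1` differs from compound 3 by hydrogen in place of 4-methylphenyl on an aromatic carbon, the change falling next to the ring atom that bears a fused ring, two ring bonds from the ring sulfur. Among the compounds with values here, no measured step removes this aryl group; the only step touching it, a 2.6-fold lower number from compound 2 to compound 3 (0.42 log units; beyond the scatter), merely swaps one substituent on the phenyl for another and was modest. With the whole ring gone, a rise in the number well beyond the scatter is expected. Compound 4 is therefore estimated to give 30 nM, with a range from 5 nM to 200 nM. The expected step is an 11-fold higher number from compound 3 to compound 4 (1.05 log units; beyond the scatter).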

Compound 4, inhibition constant: 1.9 nM
The estimate for compound 4 lay 16-fold (1.20 log units) above the measured number; measured number below the stated range.
By their numbers in this assay, from the lowest: compounds 4 and 3 (each within the scatter of the next); then compound 2; then compound 1.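

In this assay, the 4-methylphenyl group on this aromatic carbon turns out to be dispensable: hydrogen in its place gives a 1.4-fold lower number from compound 3 to compound 4 (0.15 log units; within the scatter) and so no change that can be told from the scatter. The other two aryl groups also leave the number no lower than hydrogen does, with hydrogen in place of 4-methoxyphenyl giving a 3.7-fold lower number from compound 2 to compound 4 (0.57 log units; beyond the scatter) and hydrogen in place of 4-acetylphenyl giving a 31-fold lower number from compound 1 to compound 4 (1.49 log units; beyond the scatter). No measurement shown accounts for this result.

On these data alone, whether a small group on this carbon, such as methyl, chlorine or an aminomethyl group, would keep the number this low remains open. Compound 1 carries an acetyl group on its aryl group, and that aryl group sits on a different carbon of the shared core. The measurements shown do not separate these two differences.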